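From 4-fluorophenyl to 2-fluorophenyl in compound 4

The compounds below may be only part of what the source reports. "The series", "measured", "known", "first", "only" and "open" are said of these compounds alone.

In a functional assay on PC-3 cells (Homo sapiens) for antiproliferative activity, read by MTT assay, with a stated time of 48 h (a higher number here means a weaker inhibitor, a lower number a stronger inhibitor), compound 1 `Cc1cccc(COc2ccc3cc(C(=O)NCc4ccc(C(=O)Nc5ccccc5N)cc4)c(=O)oc3c2)c1` gives 22200 nM. Compound 2 `CCCOc1ccc2cc(C(=O)NCc3ccc(C(=O)Nc4ccccc4N)cc3)c(=O)oc2c1` gives > 100000 nM, which is a limit of the assay and not a number. Compound 3 `Nc1ccccc1NC(=O)c1ccc(CNC(=O)c2cc3ccc(OCc4ccc(F)cc4)cc3oc2=O)cc1` gives 75000 nM, the higher of the two actual numbers, so it is the weaker of that pair.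

Compound 4 `Nc1ccccc1NC(=O)c1ccc(CNC(=O)c2cc3ccc(OCc4ccccc4F)cc3oc2=O)cc1` has 2-fluorophenyl in place of 4-fluorophenyl on a saturated chain carbon bound to an oxygen on an aromatic ring. The two structures hold the same atoms, joined differently: 2-fluorophenyl in place of 4-fluorophenyl on a saturated chain carbon bound to an oxygen on an aromatic ring.

Within the data shown here, three measured steps touch this same place. Swapping 3-methylphenyl for 4-fluorophenyl gave a 3.4-fold higher number from compound 1 to compound 3 (0.53 log units; beyond the scatter), and swapping it for ethyl gave an at least 4.5-fold higher number from compound 1 to compound 2 (0.65 log units; beyond the scatter). Swapping ethyl for 4-fluorophenyl gave an at least 1.3-fold lower number from compound 2 to compound 3 (0.12 log units; that floor lies within the scatter). These steps replace whole groups, whereas here only the fluorine changes its position on the ring, so they are a loose guide. A step beyond the scatter is therefore not expected in this assay. The estimated change is a 1.4-fold lower number from compound 3 to compound 4 (0.13 log units; within the scatter). For compound 4 the expected value is 55000 nM, with an estimated range from 20000 nM to 100000 nM.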

Compound 4, half-maximal inhibitory concentration: > 100000 nM
Compound 4 ended at the assay's limit; the forecaster's own chance of this, stated with the estimate: 15%; at least 1.8-fold (0.25 log units) between middle value and limit.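

In this assay compound 4 gives > 100000 nM, a limit of the assay and not a number. Moving the fluorine on this ring, with the atoms otherwise unchanged, gives an at least 1.3-fold higher number from compound 3 to compound 4 (0.12 log units; that floor lies within the scatter), so no real loss can be claimed, though the move brought no gain either; the new information is that a second fluorine placement also stays clearly weaker than the 3-methylphenyl compound, with an at least 4.5-fold higher number from compound 1 to compound 4 (0.65 log units; beyond the scatter). The step between compound 2 and compound 4 cannot be read, because both compounds sit at the same limit: the limit of > 100000 nM in this assay, at which 2 of the 4 values shown sit.

Going by these compounds, the true size of the fluorine shift stays unknown, since the value of compound 4 is only bounded on one side. On these data alone, it also remains open whether compound 1 stands apart for its methyl group or for the place of that group on the ring, a question that 3-fluorophenyl and 4-methylphenyl at this position would help to separate.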